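Removing One Methyl Group: What Cytotoxicity to Expect

A few compounds are considered here, and "the series" means these few. Any claim that something is new, unique, unknown or untested is made for them only; others in the source may bear on it.

Compound 1 `Cc1ccc(NC(=S)OCCNC(=O)c2cccnc2)cc1` was tested in an ADME assay on RAW264.7 cells (Mus musculus) for cytotoxicity, read by MTT assay, with a stated time of 48 h; on this read-out lower numbers stand for stronger inhibition and higher numbers for weaker inhibition. In this assay compound 1 gives only a limit, > 800000 nM. Compound 2 `CC(C)(Oc1ccc(Cl)cc1)C(=O)Oc1ccc(-c2cc(=S)ss2)cc1` likewise gives only a limit in this assay, > 800000 nM. Both measured values sit at the limit of > 800000 nM in this assay, at which 2 of the 2 values shown sit, so compound 1 stands at the limit itself, with no number to compare. Compound 3 `O=C(NCCOC(=S)Nc1ccccc1)c1cccnc1` has not been measured yet. It differs from compound 1 by hydrogen in place of methyl on an aromatic carbon, a change from 4-methylphenyl to phenyl. Going by the values given here, with no measured steps to draw on, the step is expected to be none beyond the usual scatter, as a number no higher from compound 1 to compound 3 (the limit leaves the size open). Compound 3 is therefore expected to give 800000 nM, between 300000 nM and 2000000 nM.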

Compound 3, half-maximal inhibitory concentration: > 800000 nM
Compound 3: no number, only a limit (the forecaster's own chance of this, stated with the estimate: 85%); the middle value lies on the limit itself.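

Compound 1 and compound 3 both give only a limit in this assay, so no step can be read between them: the limit of > 800000 nM in this assay, at which 3 of the 3 values shown sit. Going by these compounds, whether exchanging methyl for hydrogen changes cytotoxicity at all remains open.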